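From 2-methoxyphenyl to 4-methoxyphenyl: compound 4 awaits measurement

A few compounds are considered here, and "the series" means these few. Any claim that something is new, unique, unknown or untested is made for them only; others in the source may bear on it.

In a functional assay on DU-145 cells (Homo sapiens) for inhibition, read by trypan blue exclusion, with a stated time of 96 h (on this read-out higher numbers stand for weaker inhibition of growth and lower numbers for stronger inhibition of growth), compound 1 `Cc1cc(C)cc(/C=C(/SCc2ccc(F)cc2)C(=O)c2ccc(Br)cc2)c1` gives 10000 nM, compound 2 `COc1ccccc1/C=C(/SCc1ccc(F)cc1)C(=O)c1ccc(Br)cc1` gives 10000 nM and compound 3 `COc1ccccc1/C=C(/Sc1ccc(C)cc1)C(=O)c1ccc(Br)cc1` gives 9000 nM. Compound 2 thus stands level with compound 1 and within the scatter of compound 3, so the three numbers form one tight group. The next compound, compound 4 `COc1ccc(/C=C(/SCc2ccc(F)cc2)C(=O)c2ccc(Br)cc2)cc1`, has the same atoms as compound 2, joined differently: 4-methoxyphenyl in place of 2-methoxyphenyl on a double-bonded chain carbon bound to a double-bonded chain carbon. The change is 4-methoxyphenyl in place of 2-methoxyphenyl, on a double-bonded chain carbon bound to a double-bonded chain carbon. Within the data shown here, two measured steps bear on it. At that same place, 2-methoxyphenyl in place of 3,5-dimethylphenyl gave no change at the digits printed from compound 1 to compound 2 (within the scatter). At a different place, 4-methylphenyl in place of 4-fluorobenzyl on a sulfur gave a 1.1-fold lower number from compound 2 to compound 3 (0.05 log units; within the scatter). Neither step moves the methoxy group, so the data hold no direct measure of this change. Both stayed within the scatter, however, so no step beyond it is expected, although the range is left wider on the lower side. The expected size is a 1.4-fold lower number from compound 2 to compound 4 (0.15 log units; within the scatter). For compound 4 the estimated value is 7000 nM, with an expected range from 2500 nM to 12000 nM.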

Compound 4, concentration for 50% growth inhibition: 50000 nM
The estimate for compound 4 lay 7.1-fold (0.85 log units) below the measured number; measured number above the stated range.
By their numbers in this assay, from the lowest: compounds 3, 1 and 2 (each within the scatter of the next); then compound 4.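

In this assay, among these compounds, the move from 2-methoxyphenyl to 4-methoxyphenyl on a double-bonded chain carbon bound to a double-bonded chain carbon gives a 5.0-fold higher number from compound 2 to compound 4 (0.70 log units; beyond the scatter), the first step in this set to pass beyond the scatter. The two groups have the same atoms and the same counts, so the step shows that this place responds to where the methoxy group sits on the ring, even with the composition held constant. The earlier flat result at this place, no change at the digits printed from compound 1 to compound 2 (within the scatter), therefore holds only for that pair of groups, since 4-methoxyphenyl in place of 3,5-dimethylphenyl gives a 5.0-fold higher number from compound 1 to compound 4 (0.70 log units; beyond the scatter), and nothing in the data explains why the placement of the methoxy group matters here.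

From the compounds shown here alone, it remains open whether the higher number belongs to the methoxy group itself or to any group at that ring position, a question that a hydroxyl or an amine in place of the methoxy group could test. Going by these compounds, it is also open whether the same move would give a step of similar size with 4-methylphenyl on the sulfur, as in compound 3, in place of 4-fluorobenzyl.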